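Swapping methoxy for chloro in compound 3

The source may report more compounds than this note shows. Statements on the series, on what has been measured and on what is new or still open speak of the compounds shown alone.

Of the compounds shown here, three have so far been measured in a functional assay on SW620/5-FU cells (Homo sapiens) for cytotoxicity, read by MTT assay, with a stated time of 48 h, in the presence of a further agent that is not named here; on this read-out higher numbers stand for an effect only at larger amounts of compound and lower numbers for an effect already at smaller amounts. Compound 1 (`CCN(CC)c1cc(NC(=O)NNc2cc(-c3ccc(F)cc3)c3cnn(C)c3n2)cc(Cl)n1`) gives 37000 nM, compound 2 (`CCCc1cc(NNC(=O)Nc2cc(Cl)nc(Cl)c2)nc2c1cnn2C`) gives 38700 nM, and compound 3 (`COc1cc(NC(=O)NNc2cc(-c3ccc(F)cc3)c3cnn(C)c3n2)cc(Cl)n1`) gives 24100 nM. Compound 3 stands within the scatter of both others, so these three values do not separate.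

Compound 4 (`Cn1ncc2c(-c3ccc(F)cc3)cc(NNC(=O)Nc3cc(Cl)nc(Cl)c3)nc21`) has chloro in place of methoxy on an aromatic carbon. This turns 2-chloro-6-methoxypyridin-4-yl into 2,6-dichloropyridin-4-yl.

Among the measured compounds shown here, the only measured step on this aromatic carbon is a 1.5-fold lower number from compound 1 to compound 3 (0.19 log units; within the scatter), with methoxy in place of diethylamino, and it stays within the scatter. Compound 2 already carries the 2,6-dichloropyridin-4-yl group, and its 38700 nM falls in the same range, though it differs from compound 4 elsewhere on the core. For the measured compounds named here, no measured pair compares chloro with methoxy directly.

On this evidence, no step beyond the scatter is expected in this assay, and no direction is firmly indicated. The expected change is a 1.2-fold higher number from compound 3 to compound 4 (0.07 log units; within the scatter). For compound 4 the estimated value is 28000 nM, with an expected range from 12000 nM to 55000 nM.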

Compound 4, half-maximal effective concentration: 9150 nM
The estimate for compound 4 lay 3.1-fold (0.49 log units) above the measured number; the measured number lies below the stated range.
By their numbers in this assay, from the lowest: compound 4; then compounds 3, 1 and 2 (each within the scatter of the next).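

In this assay the aromatic carbon next to the ring nitrogen now shows a step beyond the scatter: chloro in place of methoxy gives a 2.6-fold lower number from compound 3 to compound 4 (0.42 log units; beyond the scatter), and chloro in place of diethylamino gives a 4.0-fold lower number from compound 1 to compound 4 (0.61 log units; beyond the scatter), whereas methoxy in place of diethylamino had stayed within the scatter with a 1.5-fold lower number from compound 1 to compound 3 (0.19 log units; within the scatter). This position therefore responds to the group it carries, and of the three groups seen there, chloro alone separates from the other two. The 2,6-dichloropyridin-4-yl group is also present in compound 2, and there 4-fluorophenyl in place of propyl on an aromatic carbon gives a 4.2-fold lower number from compound 2 to compound 4 (0.63 log units; beyond the scatter), so the lower number of compound 4 depends on that second place as well as on the chloro.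

No measurement at hand gives a reason for these steps. As far as these compounds go, it remains open whether fluoro, methyl or a plain ring hydrogen at this position would behave like chloro or like methoxy, and whether a methoxy compound with propyl on the core would show the same step.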